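Same Atoms, One Double Bond Drawn Differently

The compounds below may be only part of what the source reports. "The series", "measured", "known", "first", "only" and "open" are said of these compounds alone.

In a functional assay on U-87MG ATCC cells (Homo sapiens) for cytotoxicity, read by MTT assay, with a stated time of 48 h (a lower number here means a stronger inhibitor, a higher number a weaker inhibitor), compound 1 `C/C(=N\NC(=S)Nc1ccc(I)cc1)c1ccccn1` gives 59 nM as its reading. Compound 2 `C/C(=N/NC(=S)Nc1ccc([N+](=O)[O-])cc1)c1ccccn1` gives 160 nM as its reading, the higher of the two numbers, which makes it the weaker inhibitor of this pair by a gap beyond the usual scatter of repeat measurements.

Compound 3 `C/C(=N\NC(=S)Nc1ccc([N+](=O)[O-])cc1)c1ccccn1` has not yet been measured. It has the same atoms and bonds as compound 2 and differs only in configuration as drawn (the two compounds have the same atoms and bonds and differ only in configuration as drawn: 1 of 1 stereo elements differ; a double bond is drawn Z in compound 2 and E in compound 3): a double bond is drawn Z in compound 2 and E in compound 3. Among the compounds with values here, no measured pair here shows what such a change does in this assay, so any forecast is uncertain. The estimate stays close to compound 2 at 160 nM and leans modestly toward compound 1 at 59 nM without reaching it. The expected change is a 1.5-fold lower number from compound 2 to compound 3 (0.16 log units; within the scatter) and points to a somewhat lower number, within the usual scatter. For compound 3 the estimated value is 110 nM with an expected range from 40 nM to 300 nM around it.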

Compound 3, half-maximal inhibitory concentration: 160 nM
The estimate for compound 3 lay 1.5-fold (0.16 log units) below the measured number; the range from low to high includes it.
By their numbers in this assay, from the lowest: compound 1; then compounds 2 and 3 (each within the scatter of the next).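

In this assay, within the data shown here, redrawing the double bond gives no change at the digits printed from compound 2 to compound 3 (within the scatter), the first measured pair that tests this kind of change, and at this double bond, with nitro on the aromatic ring, the drawn configuration leaves the reading where it was. The earlier gap between compound 1 and compound 2 combined two differences, whereas nitro in place of iodo on an aromatic carbon, with the double bond now drawn alike, gives a 2.7-fold higher number from compound 1 to compound 3 (0.43 log units; beyond the scatter), so the swap of groups alone carries a gap beyond the scatter. The comparison of the two nitro compounds speaks to the double bond and to nothing else: the fact that compounds 2 and 3 differ only in the configuration as drawn.

Among these compounds, the only pair testing the double bond carries nitro, so it remains open whether the same redrawing would also leave the reading in place with iodo on the ring. From the compounds shown here alone, with just iodo and nitro at this aromatic carbon, it also remains open how an amine, a carboxylic acid or a longer chain in that place would read in this assay.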